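Compound 2 to compound 3: a larger group on the amine

A few compounds are considered here, and "the series" means these few. Any claim that something is new, unique, unknown or untested is made for them only; others in the source may bear on it.

Of the compounds shown here, two have been measured, and both stop at a limit of the assay. Compound 1 `CCCN(C[C@H]1Cc2c(cccc2N2CCNCC2)CN1)[C@H]1CCCc2cccnc21` gives a limit in a functional assay on CCRF-CEM cells for agonist activity at C-X-C chemokine receptor type 4 (Homo sapiens), read by calcium flux, with a stated time of 25 min (a higher number here means that more compound is needed for the effect, a lower number that less compound is needed), of > 30000 nM. Compound 2 `CN(C[C@H]1Cc2c(cccc2N2CCNCC2)CN1)[C@H]1CCCc2cccnc21` in this assay likewise gives a limit of > 30000 nM. The step between them, a step that the two limits leave unreadable from compound 1 to compound 2, cannot be read, since both ends rest on (the limit of > 30000 nM in this assay, at which 2 of the 2 values shown sit). Compound 2 thus stands at the limit and nowhere else on the numbers shown; no value in this series is a number.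

Compound 3 `FC1(F)CCC(CN(C[C@H]2Cc3c(cccc3N3CCNCC3)CN2)[C@H]2CCCc3cccnc32)CC1` differs from compound 2 by 4,4-difluorocyclohexyl in place of hydrogen on a saturated chain carbon bound to an amine nitrogen. Going by the values given here, only the one measured step bears on this change, as it too alters the group on the saturated chain carbon bound to the amine nitrogen, and its size is hidden by the two limits. No direction and no size can be drawn from the data, so the expected outcome is that compound 3 again reaches only the limit. Compound 3 is estimated in this assay at 40000 nM, within a range of 8000 nM to 200000 nM. The step this estimate means, a step that the limit leaves unreadable from compound 2 to compound 3, is expected to remain unreadable.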

Compound 3, half-maximal effective concentration: > 30000 nM
Compound 3 was reported as a limit; the forecaster's own chance of this, stated with the estimate: 80%; the middle value lies beyond the limit too.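

In this assay compound 3 gives > 30000 nM, which is a limit and not a number. Going by these compounds alone, no step among compound 1, compound 2 and compound 3 can be read, since all three rest on a limit: the limit of > 30000 nM in this assay, at which 3 of the 3 values shown sit. The compounds shown leave open whether any group on the saturated chain carbon bound to the amine nitrogen gives a readable value in this assay.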